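Oxime to acetyl on the aryl amide series

The source may hold more compounds than are shown below. What is called first, only, known or untested is meant among the compounds shown, and "the series" means these compounds.

Of the compounds shown here, three have numbers so far. Compound 1 `C/C(=N\O)c1ccc(NC(=O)Cn2nc(-c3ccc(Cl)cc3)nc2N)cc1` gives 7.09% in a functional assay on NCI-H322M cells (Homo sapiens) for inhibition, read by sulforhodamine B assay, with a stated time of 48 h, tested at 10 uM; a lower number here means less inhibition of growth, a higher number more inhibition of growth at the concentration tested. Compound 2 `COc1cc(-c2nc(N)n(CC(=O)Nc3ccc(/C(C)=N\O)cc3)n2)cc(OC)c1OC` gives 5.82% in this assay, and compound 3 `c1ccc(-c2nc3sc(-c4ccccc4)cn3n2)cc1` gives 11% in this assay. Compound 1 stands second highest of the three numbers; its nearest neighbour is compound 2, whose number is lower but within the scatter, and its furthest is compound 3, whose number is higher but also within the scatter. All three numbers therefore sit together, and no order among them can be read. Among the measured compounds shown here, no pair of measured compounds differs in one place, so the series gives no measured step to size a single change against.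

Compound 4 `CC(=O)c1ccc(NC(=O)Cn2nc(-c3ccc(Cl)cc3)nc2N)cc1` is not yet measured. It differs from compound 1 in one place: a group of 3 heavy atoms (2 carbon, 1 oxygen; no ring) in place of a group of 4 heavy atoms (2 carbon, 1 nitrogen, 1 oxygen; no ring), on an aromatic carbon
Acetyl enters on an aromatic carbon of a six-membered aromatic ring of carbon only, in place of the group that leaves there.

For the measured compounds named here, with no measured single-place step available and all three numbers close together, no change beyond the scatter is expected for compound 4 in this assay. Compound 4 is estimated at 7%, with a range from -4% to 18%. The step of a number 0.1 percentage points lower from compound 1 to compound 4 (within the scatter) is expected to stay within the scatter.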

Compound 4, percent growth inhibition at one concentration: 5.69%
The estimate for compound 4 lay 1.3 percentage points above the measured number; the range from low to high includes it.
By their numbers in this assay, from the lowest: compounds 4, 2, 1 and 3 (each within the scatter of the next).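

In this assay the series now has its first measured single-place step (a number 1.4 percentage points lower from compound 1 to compound 4 (within the scatter)), and it falls on the aromatic carbon para to a large group. Acetyl, with 3 heavy atoms and 0 hydrogen-bond donors, replaces a group of 4 heavy atoms with 1 hydrogen-bond donor, and this exchange produces no change that can be told from the scatter, so the donor of the leaving group shows no measurable contribution to the number at this single concentration. No measurement bearing on why the number holds accompanies this result.

On these data alone, a single step cannot show whether this position responds to anything at all, and it remains open whether an amine, a carboxylic acid or a longer chain on the same aromatic carbon would move the number beyond the scatter. As far as these compounds go, it is also open whether acetyl in place of the same group would behave alike on the core of compound 2, where the chlorophenyl group of compound 1 is replaced.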